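This account rests on a few compounds, and the source may have more. Where it says the series, first, only, none or still open, it means among the compounds named here.

Measured so far in an ADME assay on cells (Mus musculus, strain BALB/C) for cytotoxicity, read by MTT assay, with a stated time of 24 h; on this read-out higher numbers stand for lower toxicity in this test and lower numbers for higher toxicity in this test:
compound 1, `Cc1ccc(C(=O)N/N=C/c2ccccc2F)c(O)c1`, 362000 nM
compound 2, `Cc1ccc(C(=O)N/N=C/c2cc(Cl)cc(Cl)c2O)c(O)c1`, 708000 nM
compound 3, `Cc1ccc(C(=O)N/N=C/c2ccccc2O)c(O)c1`, 761000 nM

Compound 3 has the highest number of the three. Compound 2 sits within the scatter of it, while compound 1 lies beyond: a 2.1-fold higher number from compound 1 to compound 3 (0.32 log units; beyond the scatter). Compound 4, `Cc1ccc(C(=O)N/N=C/c2cc(Cl)ccc2O)c(O)c1`, differs from compound 3 in one place: chloro in place of hydrogen on an aromatic carbon. Going by the values given here, no measured step covers this exact change; the only measured step, a 2.1-fold higher number from compound 1 to compound 3 (0.32 log units; beyond the scatter), concerns a different group. The nearest hint is compound 2, which carries two chloro groups and gives a number within the scatter of compound 3. The step of a 1.1-fold lower number from compound 3 to compound 4 (0.04 log units; within the scatter) is therefore expected to stay within the scatter. Compound 4 is estimated at 700000 nM, within 350000 nM to 1400000 nM.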

Compound 4, half-maximal cytotoxic concentration: 560000 nM
For compound 4 the middle estimate is 1.3-fold (0.10 log units) above the measured one, and the stated range covers the measured number.
By their numbers in this assay, from the lowest: compounds 1, 4, 2 and 3 (each within the scatter of the next, the first and the last beyond it).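

In this assay, chloro in place of hydrogen on this aromatic carbon, para to a hydroxy group, leaves the number within the scatter (a 1.4-fold lower number from compound 3 to compound 4 (0.13 log units; within the scatter)). The second chloro of compound 2 also makes no change beyond the scatter (a 1.3-fold lower number from compound 2 to compound 4 (0.10 log units; within the scatter)), so neither single chloro step separates these compounds on this read-out. No evidence on hand bears on this result.

Still open, going by these compounds, is whether a methoxy group, an amine or a carboxylic acid on this carbon would give a step beyond the scatter.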